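From tert-butyl amide to aryl urea at the same carbonyl

A few compounds are considered here, and "the series" means these few. Any claim that something is new, unique, unknown or untested is made for them only; others in the source may bear on it.

Compound 1 `CCCC(=O)Nc1ccc2[nH]cc(C3CCN(C)CC3)c2n1`: 6.9 nM
Compound 2 `CN1CCC(c2c[nH]c3ccc(NC(=O)C(C)(C)C)nc23)CC1`: 62 nM

In an assay for binding affinity to 5-hydroxytryptamine receptor 1F (Homo sapiens), read by radioligand binding (on this read-out lower numbers stand for stronger inhibition and higher numbers for weaker inhibition), compound 2 gives the higher of the two numbers, separated from compound 1 by the step of a 9.0-fold higher number from compound 1 to compound 2 (0.95 log units; beyond the scatter). Compound 3 `CN1CCC(c2c[nH]c3ccc(NC(=O)Nc4ccc(F)cc4)nc23)CC1` differs from compound 2 by (4-fluorophenyl)amino in place of tert-butyl on a carbonyl carbon. Within the data shown here, the only measured step at this carbonyl carbon, a 9.0-fold higher number from compound 1 to compound 2 (0.95 log units; beyond the scatter), swaps one alkyl group for another and so says little about an arylamino group bearing a ring and a hydrogen-bond donor. The expected step of a 2.1-fold lower number from compound 2 to compound 3 (0.32 log units; beyond the scatter) is therefore small and uncertain in direction. Compound 3 is expected to give 30 nM, within a range of 5 nM to 180 nM.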

Compound 3, inhibition constant: 11 nM
For compound 3 the middle estimate is 2.7-fold (0.44 log units) above the measured one, within the range that was stated.
By their numbers in this assay, from the lowest: compounds 1 and 3 (each within the scatter of the next); then compound 2.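

Swapping tert-butyl for (4-fluorophenyl)amino on the carbonyl carbon gives a 5.6-fold lower number from compound 2 to compound 3 (0.75 log units; beyond the scatter), so a group with more heavy atoms than tert-butyl can still give a low number here. The same swap from propyl gives a 1.6-fold higher number from compound 1 to compound 3 (0.20 log units; within the scatter), which leaves the propyl amide and the aryl urea indistinguishable on this read-out. Nothing available explains these steps. The compounds shown do not separate the contributions of the ring, the fluorine and the added hydrogen-bond donor. A plain phenyl or a methylamino group on the same carbonyl carbon would begin to pull them apart.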